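The compounds below may be only part of what the source reports. "The series", "measured", "known", "first", "only" and "open" are said of these compounds alone.

Measured compounds in this set:

compound 1, `Cc1nc(-c2cccnc2)sc1-c1nnc(-c2ccccc2)o1`: > 100 ug/mL
compound 2, `Cc1nc(-c2cccnc2)sc1-c1nnc(-c2ccc(Cl)cc2)o1`: > 100 ug/mL
compound 3, `Cc1cccc(-c2nnc(-c3sc(-c4cccnc4)nc3C)o2)c1`: > 100 ug/mL

All three were tested in an ADME assay on HCT-116 cells (Homo sapiens) for cytotoxicity, read by MTT assay; a lower number here means that less compound is tolerated, a higher number that more compound is tolerated. In this assay compound 1 gives > 100 ug/mL, which is a limit of the assay and not a number. Compound 2 likewise gives > 100 ug/mL, again a limit. Compound 3 also gives > 100 ug/mL, once more a limit. So compound 3 stands at the same limit as the other two, and no ordering among them can be made out.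

The three measured steps, a step that the two limits leave unreadable from compound 1 to compound 2, a step that the two limits leave unreadable from compound 1 to compound 3 and a step that the two limits leave unreadable from compound 2 to compound 3, cannot be given a size because every value sits at the limit of > 100 ug/mL in this assay, at which 3 of the 3 values shown sit.

Compound 4, `Cc1nc(-c2cccnc2)sc1-c1nnc(-c2cccnc2)o1`, has not yet been tested. It differs from compound 3 in one place: pyridin-3-yl in place of 3-methylphenyl on an aromatic carbon. Among the measured compounds shown here, none of the measured steps can be read in size, so they give no direction for this change; they only show that three different groups at this position all stayed at the limit. Compound 4 is therefore expected to show a step of a number no higher from compound 3 to compound 4 (the limit leaves the size open), that is, none beyond the scatter. Compound 4 is estimated at 100 ug/mL, within a range from 50 ug/mL to 200 ug/mL, most likely reported again as a limit.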

Compound 4, half-maximal cytotoxic concentration: > 100 ug/mL
Compound 4 ended at the assay's limit; the forecaster's own chance of this, stated with the estimate: 80%; the middle value lies on the limit itself.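

The steps from compound 1, compound 2 and compound 3 to compound 4 cannot be read in this assay, because all four compounds stop at the same limit: the limit of > 100 ug/mL in this assay, at which 4 of the 4 values shown sit.

The compounds shown leave open how much of each compound the cells would tolerate in this assay, and whether the groups that change make any difference there.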